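The compounds below may be only part of what the source reports. "The series", "measured", "known", "first", "only" and "open" are said of these compounds alone.

Among the compounds with values here, compound 2 `O=c1[nH]c(=O)n([C@H]2C[C@H](O)[C@@H](COP(=O)(O)Oc3ccccc3)O2)cc1F` stands highest of the two numbers so far: in a functional assay on U-87MG ATCC cells for cytotoxicity against U-87 MG (Homo sapiens), read by MTT assay, with a stated time of 48 h (on this read-out lower numbers stand for stronger inhibition and higher numbers for weaker inhibition), compound 2 gives 33700 nM, whereas compound 1 `O=C(O[C@H]1C[C@H](n2cc(F)c(=O)[nH]c2=O)O[C@@H]1COP(=O)(O)Oc1ccccc1)c1ccccc1` gives 800 nM, the gap being a 42-fold higher number from compound 1 to compound 2 (1.62 log units; beyond the scatter). Compound 3 `O=c1[nH]c(=O)n([C@H]2C[C@H](O)[C@@H](COP(=O)(O)Oc3ccc4ncccc4c3)O2)cc1F` differs from compound 2 by quinolin-6-yl in place of phenyl on an oxygen. Within the data shown here, no measured step bears on exchanging the phenyl on this oxygen; the single known step concerns the benzoyl and is large. For compound 3 the expected step is therefore a 1.1-fold lower number from compound 2 to compound 3 (0.05 log units; within the scatter), not beyond the scatter. The estimate for compound 3 is 30000 nM, within a range of 8000 nM to 100000 nM.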

Compound 3, half-maximal inhibitory concentration: 10700 nM
Estimate against measurement, compound 3: 2.8-fold (0.45 log units) above; measured number inside the range.
By their numbers in this assay, from the lowest: compound 1; then compound 3; then compound 2.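

In this assay the group on this oxygen, whose other neighbour is phosphorus, proves able to move the number: quinolin-6-yl in place of phenyl gives a 3.1-fold lower number from compound 2 to compound 3 (0.50 log units; beyond the scatter) as a modest step, the first measured here. The entering group brings a second six-membered aromatic ring and a ring nitrogen, and this single pair cannot separate the two. Nothing available explains the step. The compounds shown leave open how a naphthyl group or an amine on this oxygen would read. They also leave open whether quinolin-6-yl gives a similar step alongside the benzoyl of compound 1.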